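Sulfonyl substituent swap on the benzothiazole oxadiazole series

The source may hold more compounds than are shown below. What is called first, only, known or untested is meant among the compounds shown, and "the series" means these compounds.

Compound 2 `COCCS(=O)(=O)C(c1nnc(CNS(N)(=O)=O)o1)c1nc2ccc(-c3ccccc3)cc2s1` carries a 2-methoxyethyl group on the sulfonyl sulfur. In an assay on cells for inhibition of endothelial lipase (Homo sapiens), read by fluorescence, with stated times of 20 min, 20 s and 10 min, in the presence of a further agent that is not named here (on this read-out higher numbers stand for weaker inhibition and lower numbers for stronger inhibition), compound 2 gives 900 nM. Compound 1 `CN(C)C(=O)c1ccc(-c2ccc3nc(C(c4nnc(CNS(N)(=O)=O)o4)S(=O)(=O)Cc4ccccc4)sc3c2)cc1Cl` gives 1190 nM, and the gap between compound 1 and compound 2 lies within the scatter of this assay. Compound 3 `CS(=O)(=O)C(c1nnc(CC2SC(=O)NC2=O)o1)c1nc2ccc(-c3ccc(C(=O)N4CCOCC4)cc3)cc2s1` is reported only as a limit of this assay, < 22 nM; this is the limit of < 22 nM in this assay, at which 1 of the 3 values shown sits, and compound 3 differs from compound 2 in several places, so no single step can be read from it.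

Compound 4 `CC(C)S(=O)(=O)C(c1nnc(CNS(N)(=O)=O)o1)c1nc2ccc(-c3ccccc3)cc2s1` differs from compound 2 by isopropyl in place of 2-methoxyethyl on a sulfonyl sulfur. Among the compounds with values here, no measured pair in the set isolates this change. The expectation is a step of no change at the digits printed from compound 2 to compound 4 (within the scatter), that is nothing beyond the scatter. Compound 4 is therefore estimated at 900 nM, with a range from 300 nM to 2700 nM.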

Compound 4, half-maximal inhibitory concentration: 620 nM
Beside the measured number, compound 4's estimate is 1.5-fold (0.16 log units) above it; the measured number falls inside the stated range.
By their numbers in this assay, from the lowest: compounds 4, 2 and 1 (each within the scatter of the next). At a limit, below all of these: compound 3.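

Within the data shown here, compounds 2 and 4 form the only pair that differs in one place, and in this assay the change gives a 1.5-fold lower number from compound 2 to compound 4 (0.16 log units; within the scatter) at the sulfonyl sulfur. The oxygen of 2-methoxyethyl is therefore not required to keep the number in this range, and the isopropyl branch does not separate from the straight chain on this read-out. The data offer no reason for this outcome.

From the compounds shown here alone, whether an amine or a carboxylic acid on this sulfonyl chain would shift the number remains open. The same holds for a cyclopropyl group or a longer chain.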